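The compounds below may be only part of what the source reports. "The series", "measured", "known", "first", "only" and "open" are said of these compounds alone.

In a functional assay on A549 cells (Homo sapiens) for inhibition, read by MTT assay, with a stated time of 72 h (on this read-out higher numbers stand for weaker inhibition and lower numbers for stronger inhibition), compound 1 `COc1ccc(C2CC2C(=O)NNc2nncc3ccccc23)cc1` gives 96000 nM; compound 2 `CC(C)=CCC/C(C)=C/COc1ccc(C2CC2C(=O)NNc2nncc3ccccc23)cc1` gives 36000 nM; compound 3 `CC(C)=CCC/C(C)=C/COc1ccc(C2CC2C(=O)NNC(=O)c2ccncc2)cc1` gives 78000 nM. Among the measured compounds shown here, compound 3 thus sits within the scatter of compound 1, while the step of a 2.2-fold higher number from compound 2 to compound 3 (0.34 log units; beyond the scatter) sets it apart from the one lower number in the set. Compound 4 `CC(C)=CCOc1ccc(C2CC2C(=O)NNC(=O)c2ccncc2)cc1` carries hydrogen in place of 3-methylbut-2-en-1-yl on a saturated chain carbon bound to a double-bonded chain carbon. For the measured compounds named here, the only measured step that touches this chain is a 2.7-fold lower number from compound 1 to compound 2 (0.43 log units; beyond the scatter), which attached the whole chain and brought a modest lowering; cutting the chain back part of the way is expected to undo part of that in this assay, so a modestly higher number is expected. The estimated step is a 1.5-fold higher number from compound 3 to compound 4 (0.17 log units; within the scatter). Compound 4 is therefore expected near 115000 nM, within 55000 nM to 250000 nM.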

Compound 4, half-maximal inhibitory concentration: > 100000 nM
Compound 4: a limit, no number; the forecaster's own chance of this, stated with the estimate: 30%; the middle value does not contradict the limit.
By their numbers in this assay, from the lowest: compound 2; then compounds 3 and 1 (each within the scatter of the next). At a limit, above all of these: compound 4.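

In this assay, compound 4 gives > 100000 nM, which is a limit and not a number. Hydrogen in place of 3-methylbut-2-en-1-yl gives an at least 1.2-fold higher number from compound 3 to compound 4 (0.10 log units; that floor lies within the scatter), so this first change of chain length on the side of compound 3 shows no lower number, while its true size stays unread. The series now reaches a limit at the upper end: the limit of > 100000 nM in this assay, at which 1 of the 4 values shown sits.

Open, from the compounds shown here alone, is how far compound 4 lies past its limit. Also open, going by these compounds, is whether a longer chain than 3,7-dimethylocta-2,6-dien-1-yl, or a carboxylic acid at the chain end, would shift the number in this assay.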